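This account rests on a few compounds, and the source may have more. Where it says the series, first, only, none or still open, it means among the compounds named here.

Working notes on the series, read in a functional assay on HL-60 cells (Homo sapiens) for inhibition, read by CCK-8 assay, with a stated time of 48 h; on this read-out lower numbers stand for stronger inhibition and higher numbers for weaker inhibition. Compound 1 `COc1ccc(Oc2ccc(C(C)C)cc2-c2ccsc2S(=O)(=O)NCCNC(=S)Nc2ccc([N+](=O)[O-])cc2)cc1OC` gives 11200 nM. Compound 3 `O=S(=O)(NCCNC(=S)Nc1cc(C(F)(F)F)cc(C(F)(F)F)c1)c1ccc(-c2ccccc2O[C@H]2CC[C@@H](O)CC2)s1` gives 2600 nM, the lower of the two actual numbers and beyond the scatter from compound 1. Compound 2 `O=S(=O)(NCCNC(=S)Nc1cc(C(F)(F)F)cc(C(F)(F)F)c1)c1ccc(-c2ccccc2OCc2cccc(O)c2)s1` reads > 50000 nM, which is a limit of the assay and not a number.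

The next change leads to compound 4 `O=S(=O)(NCCNC(=S)Nc1cc(C(F)(F)F)cc(C(F)(F)F)c1)c1ccc(-c2ccccc2OCc2ccccc2)s1`: benzyl in place of 4-hydroxycyclohexyl on an oxygen on an aromatic ring. In words, benzyl replaces 4-hydroxycyclohexyl on an oxygen on an aromatic ring.

Among the measured compounds shown here, one measured step bears on this, an at least 19-fold lower number from compound 2 to compound 3 (1.28 log units; beyond the scatter), which is large and beyond the scatter. It swaps 3-hydroxybenzyl for 4-hydroxycyclohexyl at the same place, and its size is bounded by a limit. Going back from 4-hydroxycyclohexyl to a benzyl group is therefore expected to raise the number in this assay, with the size poorly fixed by this single pair. The expected change is a 5.8-fold higher number from compound 3 to compound 4 (0.76 log units; beyond the scatter). For compound 4 the estimated value is 15000 nM, with an expected range of 4000 nM to 50000 nM.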

Compound 4, half-maximal inhibitory concentration: 2100 nM
For compound 4 the middle estimate is 7.1-fold (0.85 log units) above the measured one, and the stated range ends above it.
By their numbers in this assay, from the lowest: compounds 4 and 3 (each within the scatter of the next); then compound 1. At a limit, above all of these: compound 2.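

In this assay, benzyl and 4-hydroxycyclohexyl on the oxygen on the aromatic ring cannot be told apart: a 1.2-fold lower number from compound 3 to compound 4 (0.09 log units; within the scatter). The large gap seen earlier therefore does not separate benzyl from 4-hydroxycyclohexyl as such, but goes with the hydroxy on the benzyl group of compound 2, as hydrogen in place of that hydroxy shows: an at least 23-fold lower number from compound 2 to compound 4 (1.37 log units; beyond the scatter). The size of that step remains bounded rather than fixed, as compound 2 stands at a limit of the assay and not at a number: the limit of > 50000 nM in this assay, at which 1 of the 4 values shown sits.

Going by these compounds, it remains open whether plain cyclohexyl on the same oxygen would read like compound 3, which would show what the hydroxy contributes on that ring. Also open, on these data alone, is whether an amine or a carboxylic acid on the benzyl group, or a longer chain carrying the phenyl ring, would read like compound 4 or like compound 2.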